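A few compounds are considered here, and "the series" means these few. Any claim that something is new, unique, unknown or untested is made for them only; others in the source may bear on it.

Compound 1 `O=C(N/N=C/c1ccc(F)cc1)Nc1ccc(Oc2ccnc3[nH]ccc23)c(F)c1`: 3880 nM
Compound 2 `O=C(N/N=C/c1ccc(F)cc1Cl)Nc1ccc(Oc2ccnc3[nH]ccc23)c(F)c1`: 1110 nM
Compound 3 `O=C(N/N=C/c1ccc(O)c(Br)c1)Nc1ccc(Oc2ccnc3[nH]ccc23)c(F)c1`: not yet measured

Both measured compounds were tested in a functional assay on HepG2 cells (Homo sapiens) for antiproliferative activity, read by MTT assay, with a stated time of 72 h; a higher number here means a weaker inhibitor, a lower number a stronger inhibitor. Compound 2, at 1110 nM, has the lower number of the two and is therefore the stronger inhibitor, with a gap to compound 1 that lies beyond the scatter.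

The move to compound 3 replaces a whole substituted ring: 3-bromo-4-hydroxyphenyl in place of 2-chloro-4-fluorophenyl on a carbon with a double bond to nitrogen. In words, 3-bromo-4-hydroxyphenyl comes in place of 2-chloro-4-fluorophenyl on a carbon with a double bond to nitrogen.

Within the data shown here, only one measured step bears on this, and only loosely: a 3.5-fold lower number from compound 1 to compound 2 (0.54 log units; beyond the scatter), which came with chloro in place of hydrogen on an aromatic carbon. Among the measured compounds shown here, compound 3 gives up that chloro group, and no measured compound carries a bromo or hydroxy group, so the direction is uncertain. A modest step toward a higher number in this assay is the best expectation. The estimated change is a 2.3-fold higher number from compound 2 to compound 3 (0.35 log units; beyond the scatter). For compound 3 the estimated value is 2500 nM, with an expected range from 600 nM to 9000 nM.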

Compound 3, half-maximal inhibitory concentration: 1360 nM
Estimate against measurement, compound 3: 1.8-fold (0.26 log units) above; measured number inside the range.
By their numbers in this assay, from the lowest: compounds 2 and 3 (each within the scatter of the next); then compound 1.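

Measured by this assay the exchange of 2-chloro-4-fluorophenyl for 3-bromo-4-hydroxyphenyl on a carbon with a double bond to nitrogen gives a 1.2-fold higher number from compound 2 to compound 3 (0.09 log units; within the scatter) and so does not separate these two rings, although the entering ring carries a hydrogen-bond donor and a hydrogen-bond acceptor and the leaving ring carries neither. Set against the 4-fluorophenyl ring, the same 3-bromo-4-hydroxyphenyl ring gives a 2.9-fold lower number from compound 1 to compound 3 (0.46 log units; beyond the scatter) and this shows that a chloro group is not needed at this position to move away from the number of compound 1. Nothing available here explains why two such differently substituted rings read alike in this assay.

On these data alone, compound 3 brings in its bromo and hydroxy groups together, so what each does alone remains open, as a ring carrying only one of them would be needed to tell them apart. Also open, as far as these compounds go, is how a ring bearing a methoxy group, an amine or a carboxylic acid would read on this same carbon, and whether any such ring would reach a clearly lower number than those of compound 2 and compound 3.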